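Removing the isopropyl from a cinnamide melanin-concentrating hormone ligand

The compounds below may be only part of what the source reports. "The series", "measured", "known", "first", "only" and "open" are said of these compounds alone.

Measured compounds:
compound 1, `CCCc1cc(N)c2cc(NC(=O)CCc3ccccc3)ccc2n1`, 8300 nM
compound 2, `CCCc1cc(N)c2cc(NC(=O)/C=C/c3ccc(C(C)C)cc3)ccc2n1`, 2.9 nM

Of the compounds shown here, two have been tested in an assay on isolated protein for displacement of a labelled ligand from melanin-concentrating hormone receptor 1 (Homo sapiens); on this read-out higher numbers stand for weaker inhibition and lower numbers for stronger inhibition. Compound 1 `CCCc1cc(N)c2cc(NC(=O)CCc3ccccc3)ccc2n1` gives 8300 nM in this assay. Compound 2 `CCCc1cc(N)c2cc(NC(=O)/C=C/c3ccc(C(C)C)cc3)ccc2n1` gives 2.9 nM in this assay, the lower of the two numbers, and the gap between compound 1 and compound 2 lies well beyond the scatter. Because compound 1 and compound 2 differ in more than one place, these two values alone do not show which part of the difference carries the gap.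

Compound 3 `CCCc1cc(N)c2cc(NC(=O)/C=C/c3ccccc3)ccc2n1` has not yet been measured in this assay. It differs from compound 2 at one place: hydrogen in place of isopropyl on an aromatic carbon. For the measured compounds named here, no measured pair isolates this change, so the expectation rests on the two values alone. Compound 3 is expected to give a higher number than compound 2, with a step of a 10-fold higher number from compound 2 to compound 3 (1.01 log units; beyond the scatter) in this assay that is expected to lie beyond the scatter. The estimate for compound 3 in this assay is 30 nM, with a range from 6 nM to 200 nM.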

Compound 3, half-maximal inhibitory concentration: 1000 nM
Compound 3: the middle estimate sits 33-fold (1.52 log units) below what was measured; measured number above the stated range.
By their numbers in this assay, from the lowest: compound 2; then compound 3; then compound 1.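

In this assay, taking the isopropyl off the 4-isopropylphenyl group of compound 2 gives a 340-fold higher number from compound 2 to compound 3 (2.54 log units; beyond the scatter) and leaves only hydrogen on that aromatic carbon, so this single change, para to a large group, is a large one in this pair. Compound 3 also isolates the other difference that compound 1 and compound 2 had left tangled: with no isopropyl present, 2-phenylethenyl in place of phenethyl on the carbonyl carbon gives an 8.3-fold lower number from compound 1 to compound 3 (0.92 log units; beyond the scatter) and is beyond the scatter, although modest beside the isopropyl step. Of the two single changes now read, the loss of isopropyl is therefore the large one and the change in the chain the modest one, but nothing available here accounts for the size of either step.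

The compounds shown do not tell whether a methyl, an ethyl, a tert-butyl, a chlorine or a methoxy group on the same aromatic carbon would keep the number of compound 2 or fall toward that of compound 3. As far as these compounds go, they also leave open what an isopropyl would do on the phenethyl amide of compound 1, so whether the isopropyl step holds without the 2-phenylethenyl group remains unknown.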